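This account rests on a few compounds, and the source may have more. Where it says the series, first, only, none or still open, it means among the compounds named here.

Measured so far:
compound 1, `N=C(N)c1ccc(-c2ccc(-c3ccc(Cl)cc3)s2)s1`: 81.7%
compound 2, `COc1ccc(-c2ccc(-c3ccc(C(=N)N)o3)o2)cc1`: 71.7%

In an ADME assay on cells (Erythrocyte, Homo sapiens) for activation, read by hemolysis, with a stated time of 30 min, tested at 10 mM (a higher number here means a stronger effect of the compound at the concentration tested, a lower number a weaker effect), compound 1 gives 81.7%, the higher of the two numbers, while compound 2 gives 71.7%, a gap that lies within the scatter, so the two compounds cannot be told apart. Compound 3, `N=C(N)c1ccc(-c2ccc(-c3ccc(F)cc3)s2)s1`, differs from compound 1 in one place: fluoro in place of chloro on an aromatic carbon. Among the measured compounds shown here, no measured pair shows a step of this kind, so nothing in the data anchors its size. Compound 3 is expected to stay close to compound 1, with a step of a number 5.7 percentage points lower from compound 1 to compound 3 (within the scatter) that is not expected to go beyond the scatter. The estimate for compound 3 is 76%, within a range of 56% to 92%.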

Compound 3, a percentage reported as activity, at one concentration (the size of the read-out at that concentration, not a potency): 93.3%
Beside the measured number, compound 3's estimate is 17.3 percentage points below it, and the stated range ends below it.
By their numbers in this assay, from the lowest: compounds 2 and 1 (each within the scatter of the next); then compound 3.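

The change from chloro to fluoro moves the read-out in this assay, with a number 11.6 percentage points higher from compound 1 to compound 3 (beyond the scatter), so this aromatic carbon, para to a large group, responds to the exchange of one halogen atom for another. Among the compounds shown here, the earlier compounds offered no pair differing in one place, so this is the first step whose size can be read. Nothing at hand accounts for its direction or size.

As far as these compounds go, whether an amine or a carboxylic acid at this position would read higher or lower remains open. So does whether the same exchange would give a similar step on the core of compound 2.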